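Replacing the Acid of Compound 2 with a Methyl Amide

The compounds below may be only part of what the source reports. "The series", "measured", "known", "first", "only" and "open" are said of these compounds alone.

Measured so far:
compound 1, `O=C(NO)c1ccc(NCc2nc(-c3ccccc3)nn2-c2ccccc2)cc1`, 72.6%
compound 2, `O=C(O)c1ccc(NCc2nc(-c3ccccc3)nn2-c2ccccc2)cc1`, -0.4%

Both compounds were tested in an assay on Sf9 cells for inhibition of protein deacetylase HDAC6 (Homo sapiens), read by fluorescence, with a stated time of 40 min, tested at 100 nM; a higher number here means more inhibition at the concentration tested (going by the name of the read-out), a lower number less inhibition. Compound 1 gives 72.6%, while compound 2 gives -0.4%, the lowest of the two numbers. Among the measured compounds shown here, the one measured step, a number 73 percentage points lower from compound 1 to compound 2 (beyond the scatter), shows that swapping the hydroxyamino group for a hydroxy group on the carbonyl carbon removes essentially all inhibition.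

Compound 3, `CNC(=O)c1ccc(NCc2nc(-c3ccccc3)nn2-c2ccccc2)cc1`, has not yet been measured. It differs from compound 2 in one place: methylamino in place of hydroxy on a carbonyl carbon. For the measured compounds named here, no measured step covers this change directly. Compound 1 shows that the hydroxyamino group carries the activity, and compound 2 shows that the hydroxy group does not; nothing measured suggests that methylamino would restore it. The expectation is therefore a step of about a number 4.4 percentage points higher from compound 2 to compound 3 (within the scatter), that is, no change beyond the scatter. Compound 3 is expected to give about 4%, within a range of -10% to 22%.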

Compound 3, a percentage reported as inhibition, at one concentration (the size of the read-out at that concentration, not a potency): -3.6%
Estimate against measurement, compound 3: 7.6 percentage points above; the range from low to high includes it.
By their numbers in this assay, from the lowest: compounds 3 and 2 (each within the scatter of the next); then compound 1.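

In this assay, putting methylamino in place of hydroxy on the carbonyl carbon gives a number 3.2 percentage points lower from compound 2 to compound 3 (within the scatter), so the acid and the methyl amide cannot be told apart here. Among the compounds shown here, the more telling comparison is with the hydroxamic acid: methyl in place of hydroxy on the amide-type nitrogen gives a number 76.2 percentage points lower from compound 1 to compound 3 (beyond the scatter), which shows that keeping a nitrogen on the carbonyl carbon is not enough, and that within this set, inhibition is seen only with the hydroxy on that nitrogen. No measured evidence on the reason for this loss is available.

As far as these compounds go, whether a plain amino group or a methoxyamino group on the carbonyl carbon would keep any inhibition remains open. Also open, from the compounds shown here alone, is whether compound 2 and compound 3 would show inhibition at a higher concentration.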